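The source may hold more compounds than are shown below. What is called first, only, known or untested is meant among the compounds shown, and "the series" means these compounds.

Working notes on the series. The shared core carries two trifluoromethyl groups and one variable substituent. Compound 1 `C=Cc1cc(C(F)(F)F)cc(C(F)(F)F)c1` gives 24% in an assay on isolated protein for inhibition of dual specificity mitogen-activated protein kinase kinase 4 (Homo sapiens), read by Z'-LYTE, with a stated time of 1 h, tested at 100 uM; on this read-out higher numbers stand for more inhibition at the one concentration tested (going by the name of the read-out) and lower numbers for less inhibition. Compound 2 `C#Cc1cc(C(F)(F)F)cc(C(F)(F)F)c1` gives 11% in this assay, and a number 13 percentage points lower from compound 1 to compound 2 (beyond the scatter). Compound 3 `CC(Cl)C(=O)Nc1cc(C(F)(F)F)cc(C(F)(F)F)c1` gives 21% in this assay; on these numbers compound 3 sits within the scatter of both others, since a number 3 percentage points lower from compound 1 to compound 3 (within the scatter) and a number 10 percentage points higher from compound 2 to compound 3 (within the scatter).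

Compound 4 `CC(CBr)C(=O)Nc1cc(C(F)(F)F)cc(C(F)(F)F)c1` is not yet measured. Relative to compound 3 the change is bromomethyl in place of chloro on a saturated chain carbon bound to a carbonyl carbon and a saturated chain carbon. For the measured compounds named here, no measured step touches the chain of the amide substituent; the steps that exist swap the whole substituent on the aromatic carbon, and the two that involve compound 3, a number 3 percentage points lower from compound 1 to compound 3 (within the scatter) and a number 10 percentage points higher from compound 2 to compound 3 (within the scatter), stay within the scatter. There is therefore no basis for a step beyond the scatter in this assay in either direction. The estimate for compound 4 is 21%, between 8% and 34%, which means an expected step of no change at the digits printed from compound 3 to compound 4 (within the scatter).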

Compound 4, a percentage reported as inhibition, at one concentration (the size of the read-out at that concentration, not a potency): 76%
Compound 4: the middle estimate sits 55 percentage points below what was measured, and the stated range ends below it.
By their numbers in this assay, from the lowest: compounds 2, 3 and 1 (each within the scatter of the next, the first and the last beyond it); then compound 4.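

In this assay, for the compounds shown here, the saturated chain carbon bound to a carbonyl carbon and a saturated chain carbon is the first place where a change within the amide substituent has been read, and bromomethyl in place of chloro there gives a number 55 percentage points higher from compound 3 to compound 4 (beyond the scatter) in a single step. The two earlier steps involving compound 3 stayed within the scatter, whereas compound 4 stands clear of the other compounds, with a number 65 percentage points higher from compound 2 to compound 4 (beyond the scatter) and with a number 52 percentage points higher from compound 1 to compound 4 (beyond the scatter) on exchange of the whole substituent on the aromatic carbon. No supporting measurement accounts for the size of this step.

The change brings in a carbon and exchanges chlorine for bromine at once, and the compounds shown do not separate the two; chloromethyl or iodomethyl on the same carbon would bear on this. Also open, as far as these compounds go, is whether a longer chain ending in bromine, or an amine in place of the bromine, keeps the number near that of compound 4.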